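Chain extension on the diamine side chain

The source may report more compounds than this note shows. Statements on the series, on what has been measured and on what is new or still open speak of the compounds shown alone.

In a functional assay on SGC-7901 cells (Homo sapiens) for antiproliferative activity, in the presence of a further agent that is not named here (a higher number here means a weaker inhibitor, a lower number a stronger inhibitor), compound 1 `CC(C)(C)OC(=O)N1CCN(CCN[C@@H]2CC[C@@H](c3ccc(Cl)c(Cl)c3)c3ccccc32)CC1` gives 17100 nM. Compound 2 `NCCN[C@@H]1CC[C@H](c2ccc(Cl)c(Cl)c2)c2ccccc21` gives 10700 nM, the lower of the two numbers, though the gap to compound 1 lies within the scatter of repeated measurements. Compound 3 `NCCCCN[C@@H]1CC[C@H](c2ccc(Cl)c(Cl)c2)c2ccccc21` differs from compound 2 by 2-aminoethyl in place of amino on a saturated chain carbon, two bonds along the chain from an amine nitrogen. Within the data shown here, no step of this kind has been measured. The expected step is a 1.1-fold lower number from compound 2 to compound 3 (0.05 log units; within the scatter), none beyond the scatter. Compound 3 is estimated at 9500 nM, within 4000 nM to 25000 nM.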

Compound 3, half-maximal inhibitory concentration: 6300 nM
Compound 3: middle estimate off by 1.5-fold (0.18 log units), on the high side; low and high end bracket the measured number.
By their numbers in this assay, from the lowest: compounds 3, 2 and 1 (each within the scatter of the next, the first and the last beyond it).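

In this assay, 2-aminoethyl in place of amino on a saturated chain carbon, two bonds along the chain from an amine nitrogen, gives a 1.7-fold lower number from compound 2 to compound 3 (0.23 log units; within the scatter), so this extension of the chain, read as (2-aminoethyl)amino to (4-aminobutyl)amino, leaves compound 3 indistinguishable from compound 2. The position therefore accepts the added length with no step beyond the scatter. No available evidence bears on this result.

Open, going by these compounds, is whether a longer chain would give a step beyond the scatter. Also open, on these data alone, is whether a carboxylic acid in place of the amine would do so.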